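The compounds below may be only part of what the source reports. "The series", "measured", "known", "first", "only" and "open" are said of these compounds alone.

Measured so far:
compound 1 `CC(C)(C)c1ccc(NC(=O)CCc2cccc3c2B(O)OC3)cc1` gives 19000 nM
compound 2 `CC(C)c1cccc(NC(=O)CCc2cccc3c2B(O)OC3)c1` gives 1600 nM
compound 3 `Cc1cc(C)c(NC(=O)CCc2cccc3c2B(O)OC3)c(C)c1` gives 64000 nM

All three numbers come from a functional assay on HCT-116 cells (Homo sapiens) for antiproliferative activity, read by MTT assay, with a stated time of 72 h (a higher number here means a weaker inhibitor, a lower number a stronger inhibitor), and belong to compounds that share one core but carry different groups. Compound 2 has the lowest number of the three. Its gaps to compound 1 and to compound 3 both lie beyond the scatter of repeat measurements, so it is the strongest inhibitor in this small set.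

Compound 4 `COc1cc(OC)cc(-c2cccc(NC(=O)CCc3cccc4c3B(O)OC4)c2)c1` has not yet been measured. It has 3,5-dimethoxyphenyl in place of isopropyl on an aromatic carbon of compound 2, a change counted as 3,5-dimethoxyphenyl in place of isopropyl on an aromatic carbon and sitting meta to a large group.

Among the compounds with values here, no two measured compounds differ in one place alone, so no single change can be read directly, and none of them carries the new group. The values do show that compound 1 at 19000 nM and compound 3 at 64000 nM both lie above compound 2 at 1600 nM in this set. A move away from compound 2 is therefore expected to raise the number moderately, by less than either of those gaps. The expected change is a 2.5-fold higher number from compound 2 to compound 4 (0.40 log units; beyond the scatter) in this estimate. Compound 4 is estimated at 4000 nM in this assay with a range from 600 nM to 25000 nM as the expected spread.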

Compound 4, half-maximal inhibitory concentration: 53 nM
Compound 4: middle estimate off by 75-fold (1.88 log units), on the high side; measured number below the stated range.
By their numbers in this assay, from the lowest: compound 4; then compound 2; then compound 1; then compound 3.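

In this assay, within the data shown here, replacing isopropyl with 3,5-dimethoxyphenyl on an aromatic carbon, meta to a large group, gives a 30-fold lower number from compound 2 to compound 4 (1.48 log units; beyond the scatter), and this is the first single change that can be read directly. It shows that this position of the shared core accommodates a far larger group than isopropyl, with a strong gain in antiproliferative activity rather than a loss. The change adds a six-membered aromatic ring and hydrogen-bond acceptors together, but no measurement here explains why the number falls.

The compounds shown leave open whether the added ring alone accounts for the drop or whether its two methoxy groups also contribute, a question that a plain phenyl group at this carbon could help to separate. Also open, on these data alone, is how far the position tolerates other kinds of substituent on that ring, such as an amine or a carboxylic acid in place of the methoxy groups.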